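Swapping the amide-bound aryl group: from ester to nitrile

The source may report more compounds than this note shows. Statements on the series, on what has been measured and on what is new or still open speak of the compounds shown alone.

Three compounds sharing one core differ only in the aryl group on one amide-type nitrogen. In a functional assay on A549 cells (Homo sapiens) for inhibition, read by CCK-8 assay, with a stated time of 72 h, tested at 1 uM (a lower number here means less inhibition of growth, a higher number more inhibition of growth at the concentration tested), compound 1 `CN(C)C(=O)c1cc2cnc(Nc3ccc(NC(=O)C4(C(=O)Nc5ccccc5)CC4)cc3)nc2n1C1CCCC1` gives 75%. Compound 2 `Cc1ccc(NC(=O)C2(C(=O)Nc3ccc(Nc4ncc5cc(C(=O)N(C)C)n(C6CCCC6)c5n4)cc3)CC2)cc1` gives 40.2%, and compound 3 `COC(=O)c1cccc(NC(=O)C2(C(=O)Nc3ccc(Nc4ncc5cc(C(=O)N(C)C)n(C6CCCC6)c5n4)cc3)CC2)c1` gives 10.5%, the lowest of the three. Both substituted rings fall below the unsubstituted one: a number 34.8 percentage points lower from compound 1 to compound 2 (beyond the scatter) and a number 64.5 percentage points lower from compound 1 to compound 3 (beyond the scatter), and between the two substituted rings a number 29.7 percentage points lower from compound 2 to compound 3 (beyond the scatter).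

Compound 4 `CN(C)C(=O)c1cc2cnc(Nc3ccc(NC(=O)C4(C(=O)Nc5ccc(C#N)cc5)CC4)cc3)nc2n1C1CCCC1` carries 4-cyanophenyl in place of 3-(methoxycarbonyl)phenyl on an amide-type nitrogen. Going by the values given here, two measured steps bear on this change. The step from compound 1 to compound 3 shows how much the methoxycarbonyl group, which now leaves, had lowered inhibition, and the step from compound 2 to compound 3 shows that exchanging one aryl group for another on this nitrogen moved the number by a modest amount. Among the compounds with values here, no measured compound carries a nitrile, so how the entering group behaves is unknown; the pattern of compounds 2 and 3 suggests a substituted ring stays below compound 1. An upward step is therefore expected, estimated as a number 21.5 percentage points higher from compound 3 to compound 4 (beyond the scatter). For compound 4 the expected value is 32%, within a range from 12% to 58%.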

Compound 4, percent growth inhibition at one concentration: 86.1%
Beside the measured number, compound 4's estimate is 54.1 percentage points below it; measured number outside the range, above it.
By their numbers in this assay, from the lowest: compound 3; then compound 2; then compound 1; then compound 4.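

In this assay, going by these compounds alone, the earlier compounds placed every substituted ring below the unsubstituted ring of compound 1, but compound 4 goes against that pattern: a number 11.1 percentage points higher from compound 1 to compound 4 (beyond the scatter) is a modest rise that makes compound 4 the highest of the four. The comparison of 4-methylphenyl with 4-cyanophenyl keeps the place on the ring and changes only the group, and the result, a number 45.9 percentage points higher from compound 2 to compound 4 (beyond the scatter) in this large step, shows that the choice of group matters here and not only whether the ring carries one. The exchange of 3-(methoxycarbonyl)phenyl for 4-cyanophenyl gives the largest step in the set, a number 75.6 percentage points higher from compound 3 to compound 4 (beyond the scatter) in all, but it changes the group and its place on the ring together, and these two changes cannot be told apart from this one step.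

The compounds shown leave open how a nitrile would behave on 3-cyanophenyl, and whether an amine or a carboxylic acid on the ring would also raise the number. No evidence is available to explain these differences.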